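Chloro in Place of Amino on a Factor X Inhibitor

The source may report more compounds than this note shows. Statements on the series, on what has been measured and on what is new or still open speak of the compounds shown alone.

Compound 1, `COc1ccc2ccc(S(=O)(=O)NC3CCN(Cc4cc5c(N)nccc5s4)C3=O)cc2c1`: 250 nM
Compound 2, `COc1ccc2ccc(S(=O)(=O)N[C@H]3CCN(Cc4ccc5ccnc(N)c5c4)C3=O)cc2c1`: 180 nM

Both compounds were tested in an assay on isolated protein for inhibition of coagulation factor X (Bos taurus); on this read-out lower numbers stand for stronger inhibition and higher numbers for weaker inhibition. Compound 2 gives the lower of the two numbers, but its distance from compound 1 is within the usual scatter of repeated measurements, so the two cannot be told apart on these data.

Compound 3, `COc1ccc2ccc(S(=O)(=O)N[C@H]3CCN(Cc4ccc5ccnc(Cl)c5c4)C3=O)cc2c1`, has not been measured. It differs from compound 2 in one place: chloro in place of amino on an aromatic carbon. Among the measured compounds shown here, no pair of measured compounds shows a change of this kind, so nothing measured here tells how large such a step is.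

The expectation for compound 3 is a clear step toward weaker inhibition in this assay, well beyond the scatter, from compound 2 to compound 3 of a 17-fold higher number from compound 2 to compound 3 (1.22 log units; beyond the scatter). Compound 3 is therefore estimated at 3000 nM, with a plausible range from 600 nM to 15000 nM.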

Compound 3, inhibition constant: > 1200 nM
Compound 3 ended at the assay's limit (the forecaster's own chance of this, stated with the estimate: 15%); the middle value does not contradict the limit.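

Among the compounds shown here, compound 3 gives the first reading of a change at this position, the carbon next to the ring nitrogen. In this assay, chloro in place of amino produces an at least 6.6-fold higher number from compound 2 to compound 3 (0.82 log units; beyond the scatter), so at this position in compound 2 the amino group cannot be exchanged for chloro without a clear loss of inhibition, even though the two groups are each a single heavy atom at the point of attachment. The value of compound 3, > 1200 nM, is a limit of the assay and not a number, so the step gives only a minimum size: the limit of > 1200 nM in this assay, at which 1 of the 3 values shown sits.

The compounds shown leave open how much further the true value of compound 3 lies beyond this limit. They also leave open whether another group on this carbon, such as hydroxyl or methylamino, would keep the inhibition seen with amino.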